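The source may hold more compounds than are shown below. What is called first, only, known or untested is meant among the compounds shown, and "the series" means these compounds.

Measured compounds:
- compound 1 `NC1=NC2(CCOCC2)N(OCCCOc2ccc(Cl)cc2)C(N)=N1`: 33.6 nM in an assay on isolated protein for inhibition of Dihydrofolate reductase (Homo sapiens), read by spectrophotometry, using NADPH, with stated times of 5 s and 6 min; on this read-out higher numbers stand for weaker inhibition and lower numbers for stronger inhibition
- compound 2 `NC1=NC2(CCSCC2)N(OCCCOc2ccc(Br)cc2)C(N)=N1`: 6.46 nM
- compound 3 `NC1=NC2(CCSCC2)N(OCCCOc2cccc(Cl)c2Cl)C(N)=N1`: "not determined" (no result reported)

Going by the values given here, compound 1 gives the highest of the two numbers recorded; the only other number, that of compound 2, is lower by a margin beyond the usual scatter, and compound 3 contributes no value. Compound 4 `NC1=NC2(CCOCC2)N(OCCCOc2ccc(Cl)cc2Cl)C(N)=N1` differs from compound 1 by chloro in place of hydrogen on an aromatic carbon, the change reading as 4-chlorophenyl to 2,4-dichlorophenyl. Among the compounds with values here, no measured pair shows this change on its own, so no size can be read from the data. The step of a 2.1-fold lower number from compound 1 to compound 4 (0.32 log units; beyond the scatter) is expected to be modest and in the direction of stronger inhibition. Compound 4 is therefore estimated at 16 nM, within 4 nM to 60 nM.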

Compound 4, half-maximal inhibitory concentration: 7.46 nM
Beside the measured number, compound 4's estimate is 2.1-fold (0.33 log units) above it; the measured number falls inside the stated range.
By their numbers in this assay, from the lowest: compounds 2 and 4 (each within the scatter of the next); then compound 1.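

In this assay, going by these compounds alone, chloro in place of hydrogen on an aromatic carbon, ortho to a large group, gives the first single-change step in the set (a 4.5-fold lower number from compound 1 to compound 4 (0.65 log units; beyond the scatter)). The earlier compounds shown here differed in more than one place, so they could not show that adding chloro at this position strengthens inhibition, here beyond the scatter. Nothing measured here accounts for the step.

On these data alone, whether an amine, a methoxy group or a carboxylic acid at this position would act in the same way remains open. So does whether chloro gives a similar step on the core of compound 2.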